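The compounds below may be only part of what the source reports. "The series", "measured", "known", "first", "only" and "open" are said of these compounds alone.

Series notes. Compound 3 `CCN(CC)c1cc(C)c2cc(N(C)C(=O)/C=C/c3ccco3)ccc2n1` stands highest of the three numbers in an assay on cells for inhibition of TP53-binding protein 1 (Homo sapiens), read by AlphaScreen, with a stated time of 30 min; a lower number here means a stronger inhibitor, a higher number a weaker inhibitor: compound 3 gives 17800 nM, while compound 1 `Cc1cc(N2CCCCC2)nc2ccc(NC(=O)/C=C/c3ccco3)cc12` gives 15100 nM and compound 2 `Cc1cc(N(C)C)nc2ccc(NC(=O)/C=C/c3ccco3)cc12` gives 4200 nM. Going by the values given here, the only step measured so far, a 3.6-fold lower number from compound 1 to compound 2 (0.56 log units; beyond the scatter), concerns the amine on an aromatic carbon and not the amide-type nitrogen. Compound 4 `CCN(CC)c1cc(C)c2cc(NC(=O)/C=C/c3ccco3)ccc2n1` differs from compound 3 by hydrogen in place of methyl on an amide-type nitrogen. Among the compounds with values here, no measured step covers this change; compounds 1 and 2 both carry the amide hydrogen, and their values give the only guide to where an amide-hydrogen analogue with a diethylamino group might fall. Compound 4 is therefore expected to give about 7000 nM in this assay, with a range of 2500 nM to 20000 nM. That estimate means a step of a 2.5-fold lower number from compound 3 to compound 4 (0.41 log units; beyond the scatter), expected with low confidence in direction.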

Compound 4, half-maximal inhibitory concentration: 1690 nM
Beside the measured number, compound 4's estimate is 4.1-fold (0.62 log units) above it, outside the stated range (below it).
By their numbers in this assay, from the lowest: compound 4; then compound 2; then compounds 1 and 3 (each within the scatter of the next).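

Going by these compounds alone, at this amide-type nitrogen, hydrogen in place of methyl gives an 11-fold lower number from compound 3 to compound 4 (1.02 log units; beyond the scatter) in this assay, the first reading of this position, as compounds 1 and 2 both carry the amide hydrogen. With that hydrogen kept, diethylamino on an aromatic carbon gives a 2.5-fold lower number from compound 2 to compound 4 (0.40 log units; beyond the scatter) against dimethylamino and an 8.9-fold lower number from compound 1 to compound 4 (0.95 log units; beyond the scatter) against piperidin-1-yl, placing compound 4 lowest of the series. No data here explain these steps. Open, from the compounds shown here alone, are whether ethyl on the amide-type nitrogen tracks methyl and whether dipropylamino on the aromatic carbon lowers the number further.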